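Swapping a methyl for fluoro on the sulfonyl phenyl ring

The source may hold more compounds than are shown below. What is called first, only, known or untested is meant among the compounds shown, and "the series" means these compounds.

Of the compounds shown here, three sharing one core have been measured in an ADME assay on Vero cells (Chlorocebus sabaeus) for cytotoxicity, read by polymerase chain reaction, with a stated time of 18 h; on this read-out higher numbers stand for lower toxicity in this test and lower numbers for higher toxicity in this test. Compound 1 `O=c1cc(CSc2nc3ccccc3c(=O)[nH]2)c2ccc(OS(=O)(=O)c3ccc(F)cc3)cc2o1` gives 30000 nM. Compound 2 `Cc1ccc2nc(SCc3cc(=O)oc4cc(OS(=O)(=O)c5ccccc5)ccc34)[nH]c(=O)c2c1` gives 126000 nM. Compound 3 `Cc1ccc(S(=O)(=O)Oc2ccc3c(CSc4nc5ccc(C)cc5c(=O)[nH]4)cc(=O)oc3c2)cc1` gives 114000 nM. Within the data shown here, the one step measured so far, a 1.1-fold lower number from compound 2 to compound 3 (0.04 log units; within the scatter), adds a methyl on the core and changes little. Compound 3 therefore stands second highest of the three numbers, close to compound 2, while compound 1 sits a good way lower, beyond the scatter.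

Compound 4 `Cc1ccc2nc(SCc3cc(=O)oc4cc(OS(=O)(=O)c5ccc(F)cc5)ccc34)[nH]c(=O)c2c1` differs from compound 3 by fluoro in place of methyl on an aromatic carbon. Among the measured compounds shown here, no measured step covers this exact exchange. The methyl-versus-hydrogen step on the core does not speak to it. What does bear on it is the pair compound 1 and compound 2, which differ only in having fluoro or hydrogen on that same phenyl ring: compound 1 with fluoro sits well below compound 2 with hydrogen. On that basis the fluoro compound is expected to land lower than compound 3, and compound 4 is estimated at 45000 nM, within 15000 nM to 130000 nM, a step of a 2.5-fold lower number from compound 3 to compound 4 (0.40 log units; beyond the scatter) expected because compound 1 shows 30000 nM against compound 2 at 126000 nM.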

Compound 4, half-maximal cytotoxic concentration: 86400 nM
For compound 4 the middle estimate is 1.9-fold (0.28 log units) below the measured one; measured number inside the range.
By their numbers in this assay, from the lowest: compound 1; then compounds 4, 3 and 2 (each within the scatter of the next).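

In this assay, this position on the sulfonyl phenyl ring looks tolerant when the methyl is present on the core: fluoro in place of methyl gives a 1.3-fold lower number from compound 3 to compound 4 (0.12 log units; within the scatter), and fluoro in place of hydrogen gives a 1.5-fold lower number from compound 2 to compound 4 (0.16 log units; within the scatter). Among these compounds, the one new step beyond the scatter comes from the other end of the molecule, where a methyl in place of hydrogen on the core, with fluoro kept on the sulfonyl phenyl ring, gives a 2.9-fold higher number from compound 1 to compound 4 (0.46 log units; beyond the scatter). The core methyl therefore counts for much more alongside the 4-fluorophenyl group than alongside the unsubstituted phenyl ring, so its effect depends on what the ring carries: the same change on two cores in this assay, a 1.1-fold lower number (0.04 log units; within the scatter) from compound 2 to compound 3 and a 2.9-fold higher number (0.46 log units; beyond the scatter) from compound 1 to compound 4, 3.2-fold (0.50 log units) apart, beyond the scatter of two such steps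

The compounds shown leave open whether this larger step is tied to fluoro or would also appear with a chloro or methoxy group at the same ring carbon. They also leave open how the number would respond to something other than methyl on the core, such as an amine or a longer chain.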